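A few compounds are considered here, and "the series" means these few. Any claim that something is new, unique, unknown or untested is made for them only; others in the source may bear on it.

Compound 2 `COc1cc(Cl)cc(-c2nn(-c3cccc(NC(=O)Nc4ccc(Cl)c(C(F)(F)F)c4)c3)cc2-c2ccncc2)c1` belongs to a small group of three urea-linked analogues sharing one core. In a functional assay on UO-31 cells (Homo sapiens) for inhibition, read by sulforhodamine B assay, with a stated time of 48 h, tested at 10 uM (on this read-out higher numbers stand for a weaker effect at the one concentration tested and lower numbers for a stronger effect), compound 2 gives 11.1%, the second highest of the three numbers. Going by the values given here, its nearest neighbour is compound 1 `O=C(Nc1cccc(-n2cc(-c3ccncc3)c(-c3cc(O)cc(Cl)c3)n2)c1)Nc1ccc(Cl)c(C(F)(F)F)c1`, which in this assay gives 18.5%; the only single-point step on record, a number 7.4 percentage points lower from compound 1 to compound 2 (within the scatter), lies within the scatter. Among the compounds with values here, the furthest is compound 3 `COc1cc(Cl)cc(-c2nn(-c3cccc(NC(=O)Nc4cc(C(F)(F)F)cc(C(F)(F)F)c4)c3)cc2-c2ccncc2)c1`, which in this assay gives -0.18%, a number beyond the scatter below that of compound 2; the two differ in the aryl group carried by the urea, for which no step is tabulated, so only the two values themselves can be compared.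

Compound 4 `COc1cc(Cl)cc(-c2nn(-c3cccc(NC(=O)c4cccc(C(F)(F)F)c4)c3)cc2-c2ccncc2)c1` is drawn from compound 2 by 3-(trifluoromethyl)phenyl in place of (4-chloro-3-(trifluoromethyl)phenyl)amino on a carbonyl carbon. Within the data shown here, no measured step touches this part of the molecule: the one step on record concerns the methyl on the oxygen and was within the scatter, while compounds 2 and 3 show that altering the group beyond the urea can move the number beyond the scatter. On this basis compound 4 is expected to sit near compound 2 or somewhat lower, with the step of a number 5.1 percentage points lower from compound 2 to compound 4 (within the scatter) carrying wide uncertainty. The estimate for compound 4 in this assay is 6%, ranging from -10% to 22%.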

Compound 4, a percentage reported as activity, at one concentration (the size of the read-out at that concentration, not a potency): 37.3%
Compound 4: the middle estimate sits 31.3 percentage points below what was measured; measured number outside the range, above it.
By their numbers in this assay, from the lowest: compound 3; then compounds 2 and 1 (each within the scatter of the next); then compound 4.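

In this assay, placing 3-(trifluoromethyl)phenyl on the carbonyl carbon in place of (4-chloro-3-(trifluoromethyl)phenyl)amino gives a number 26.2 percentage points higher from compound 2 to compound 4 (beyond the scatter), the only step shown at this position. It shows that the group on this carbonyl carbon can shift the read-out beyond the scatter towards a weaker effect at the one concentration tested, whereas the step at the oxygen stayed within the scatter. The change removes the amino nitrogen, with its hydrogen-bond donor, and the chlorine together, and nothing at hand explains the shift or assigns it to either loss.

The compounds shown leave open whether the amino nitrogen or the chlorine accounts for the shift, since none of them keeps one while losing the other. They also leave open how the read-out would respond to a simple aliphatic group on the carbonyl carbon, such as a piperidine or a short alkyl chain, in place of the aromatic ring.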